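The source may hold more compounds than are shown below. What is called first, only, known or untested is meant among the compounds shown, and "the series" means these compounds.

Working notes on the series in an ADME assay on LLC-MK2 cells (Macaca mulatta) for cytotoxicity, read by spectrophotometry and crystal violet staining, with a stated time of 4 days; a higher number here means that more compound is tolerated, a lower number that less compound is tolerated. Compound 1 `CC(C)n1ccc2c(C(=O)Nc3ccccn3)cc(-c3cccs3)nc21` returns only the limit of the assay, > 200000 nM, not a number. Compound 2 `CC(C)n1ccc2c(C(=O)Nc3cccnc3)cc(-c3cccs3)nc21` gives 25000 nM. Compound 3 `CC(C)n1ncc2c(C(=O)Nc3cccnc3)cc(-c3cccs3)nc21` likewise returns only the limit, > 200000 nM. Among the compounds with values here, the single counted step among the measured compounds is an at least 8.0-fold higher number from compound 2 to compound 1 (0.90 log units; beyond the scatter), the change being (pyridin-2-yl in place of pyridin-3-yl on an amide-type nitrogen); its true size is known only as a bound, because compound 1 sits at the limit of > 200000 nM in this assay, at which 2 of the 3 values shown sit. How the core of compound 3 differs from the core of compound 2 is not broken down here. Compound 4 `CC(C)n1ncc2c(C(=O)Nc3ccccn3)cc(-c3cccs3)nc21` remains to be measured; relative to compound 3 it carries pyridin-2-yl in place of pyridin-3-yl on an amide-type nitrogen, the same change at the same place as that from compound 2 to compound 1. For compound 4 the step expected in this assay is a step that the limit leaves unreadable from compound 3 to compound 4, resting on the direction of an at least 8.0-fold higher number from compound 2 to compound 1 (0.90 log units; beyond the scatter). Compound 3 already returns only the limit, so no numerical gain can show. Compound 4 is therefore estimated at 250000 nM, most likely again reported as a limit, within 100000 nM to 600000 nM.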

Compound 4, half-maximal cytotoxic concentration: > 200000 nM
Compound 4 ended at the assay's limit; the forecaster's own chance of this, stated with the estimate: 85%; the middle value lies beyond the limit too.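

In this assay compound 3 and compound 4 both return only a limit, not a number, so no step between them can be read: the limit of > 200000 nM in this assay, at which 3 of the 4 values shown sit.

The compounds shown leave open whether pyridin-2-yl in place of pyridin-3-yl on an amide-type nitrogen changes the number on the core of compound 3 as it does on the core of compound 2.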